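Swapping the aryl halide on the piperazine nitrogen

This account rests on a few compounds, and the source may have more. Where it says the series, first, only, none or still open, it means among the compounds named here.

Compound 1, with structure `CCC(C(=O)N1CCN(c2cccc(Cl)c2)CC1)N1C(=O)CCC1=O`, is the stronger of the two measured compounds. In a functional assay on the whole organism (strain Swiss) with Mus musculus as the target, in the maximal electroshock model, with a stated time of 1 h, at a dose of 300 mg/kg by the intraperitoneal route (a lower number here means a weaker effect, a higher number a stronger effect of the compound at the dose given), compound 1 reaches 100%. Compound 2, with structure `CC(C(=O)N1CCN(c2ccccc2C(F)(F)F)CC1)N1C(=O)CCC1=O`, differs from it in more than one place, and in this assay compound 2 gives 75%, a reading well below that of compound 1 and beyond the usual scatter.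

Compound 3, with structure `CCC(C(=O)N1CCN(c2ccccc2F)CC1)N1C(=O)CCC1=O`, is not yet measured. Among the measured compounds shown here, it keeps the shared core of compound 1 and changes only one group: 2-fluorophenyl in place of 3-chlorophenyl on an amine nitrogen in a ring. For the measured compounds named here, no measured pair shows exactly this exchange, so the size of the step is open. Since the measured reading of compound 1 already sits at the top of the scale, any shift can only be downward or none beyond the scatter; a small drop is the expectation here. For compound 3 the expected reading in this assay is 85%, with a range from 60% to 100%, an expected step of a number 15 percentage points lower from compound 1 to compound 3 (beyond the scatter).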

Compound 3, a percentage reported as activity, at one dose (the size of the read-out at that dose, not a potency): 50%
The estimate for compound 3 lay 35 percentage points above the measured number; the whole stated range lies above it.
By their numbers in this assay, from the lowest: compound 3; then compound 2; then compound 1.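

Placing 2-fluorophenyl where compound 1 carries 3-chlorophenyl, on an amine nitrogen in a ring, gives in this assay a number 50 percentage points lower from compound 1 to compound 3 (beyond the scatter). Among the compounds shown here, this is the first pair here that differs in one place only, and it shows that the reading at this dose responds strongly to this group, even though both groups have the same heavy-atom count, the same kind of aromatic ring and no hydrogen-bond donors or acceptors. Nothing available here bears on what lies behind the drop.

The change alters both the halogen and its place on the phenyl ring, so the step cannot say which of the two matters. A phenyl ring carrying chlorine where compound 3 carries fluorine would separate the two, and a plain phenyl group would show what the halogen contributes at all.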